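Chloro in place of fluoro on the shared core

The source may hold more compounds than are shown below. What is called first, only, known or untested is meant among the compounds shown, and "the series" means these compounds.

Two compounds of the shared core carry numbers in a functional assay (aorta) with Rattus norvegicus as the target (a higher number here means that more compound is needed for the effect, a lower number that less compound is needed), so far. Compound 1 `CC(C)NC1=NS(=O)(=O)c2cc(Cl)ccc2N1` gives 36.3 uM in this assay. Compound 2 `CCCNC1=NS(=O)(=O)c2cc(F)ccc2N1` gives 166 uM in this assay, the higher of the two numbers, and its gap to compound 1 lies beyond the scatter. Within the data shown here, compound 2 differs from compound 1 in more than one place, so no single-change step connects them. Compound 3 `CCCNC1=NS(=O)(=O)c2cc(Cl)ccc2N1` is the not yet measured member; it keeps the rest of compound 2 and carries the change (chloro in place of fluoro on an aromatic carbon). Among the measured compounds shown here, because compound 1, the only chloro analogue with a number, gives 36.3 uM in this assay, a downward step beyond the scatter is expected: a 2.8-fold lower number from compound 2 to compound 3 (0.44 log units; beyond the scatter). For compound 3 the value in this assay is estimated at 60 uM, with a range from 25 uM to 150 uM.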

Compound 3, concentration for half-maximal effect: 55.5 uM
Compound 3: the middle estimate sits 1.1-fold (0.03 log units) above what was measured; the range from low to high includes it.
By their numbers in this assay, from the lowest: compounds 1 and 3 (each within the scatter of the next); then compound 2.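

In this assay, chloro in place of fluoro on an aromatic carbon can now be read as a single change with propyl held constant on the amine nitrogen: the result is a 3.0-fold lower number from compound 2 to compound 3 (0.48 log units; beyond the scatter) and counts as a modest step. With chloro held constant, propyl in place of isopropyl on an amine nitrogen gives a 1.5-fold higher number from compound 1 to compound 3 (0.18 log units; within the scatter) and so, of the two single changes, only the chloro step lies beyond the scatter. No available evidence bears on the reason for this step.

The compounds shown do not tell whether the step from fluoro to chloro carries over to isopropyl or to a longer chain on the amine nitrogen. They also leave open how bromo, methyl or trifluoromethyl on this aromatic carbon would compare with chloro.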